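The source may report more compounds than this note shows. Statements on the series, on what has been measured and on what is new or still open speak of the compounds shown alone.

Within the data shown here, compound 1 `CCN(CC)C(=O)CN(c1cc2c(C)nsc2cc1Cl)S(=O)(=O)c1ccc(OC)c(OC)c1` is the only compound here with a true number: in a functional assay on CHO cells for inhibition of Orexin/Hypocretin receptor type 1 (Homo sapiens), read by FLIPR and calcium flux (on this read-out lower numbers stand for stronger inhibition and higher numbers for weaker inhibition), compound 1 gives 29 nM. Compound 2 `CCN(CC)C(=O)CN(c1cccc(N(C)C)c1C#N)S(=O)(=O)c1ccc(OC)c(OC)c1` reaches only a limit, giving in this assay > 10000 nM rather than a number. Compound 3 `CCN(CC)C(=O)CN(c1ccc(C)cc1)S(=O)(=O)c1ccccc1F` likewise sits at a limit, giving in this assay > 10000 nM. Among the measured compounds shown here, the single measured step, an at least 340-fold higher number from compound 1 to compound 2 (2.53 log units; beyond the scatter), alters the group on the sulfonamide nitrogen, not the part changed here. Compound 4 `CCN(CC)C(=O)CN(c1ccc(C)cc1)S(=O)(=O)c1ccc(Br)cc1` differs from compound 3 by 4-bromophenyl in place of 2-fluorophenyl on a sulfonyl sulfur. For the measured compounds named here, no measured step touches the sulfonyl side, so neither direction nor size can be read from the data, and compound 3 rests at the limit of > 10000 nM in this assay, at which 2 of the 3 values shown sit. Compound 4 is therefore expected to stay near that limit, an estimated step of a number no higher from compound 3 to compound 4 (the limit leaves the size open). The estimate for compound 4 is 10000 nM, from 2000 nM to 50000 nM.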

Compound 4, half-maximal inhibitory concentration: > 10000 nM
Compound 4 gave a limit, no number; the forecaster's own chance of this, stated with the estimate: 70%; the middle value lies on the limit itself.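

Among these compounds, compound 3 and compound 4 both end at a limit rather than a number, so no step between them can be read: the limit of > 10000 nM in this assay, at which 3 of the 4 values shown sit. From the compounds shown here alone, whether 4-bromophenyl in place of 2-fluorophenyl changes inhibition at all remains open.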